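Swapping 1-methylcyclopropyl for 2-methylcyclopropyl in compound 2

The source may hold more compounds than are shown below. What is called first, only, known or untested is meant among the compounds shown, and "the series" means these compounds.

In a physicochemical assay for lipophilicity, read by HPLC (on this read-out higher numbers stand for higher lipophilicity and lower numbers for lower lipophilicity), compound 2 `C[C@@H]1CN(c2nc(-c3cnn(C)c3)ncc2C#N)CCN1C(=O)C1(C)CC1` gives 1.7. Compound 3 `C[C@@H]1CN(c2cnc(C#N)c(-c3cnn(C)c3)n2)CCN1C(=O)C1CC1` gives 1.8, and compound 1 `C[C@@H]1C[C@H]1C(=O)N1CCN(c2nc(-c3cnn(C)c3)ncc2C#N)C[C@H]1C` gives 1.9. All three lie within the usual scatter of one another, so compound 2 stands level with the other two rather than apart from them.

Still unmeasured is compound 4 `CC1CC1C(=O)N1CCN(c2nc(-c3cnn(C)c3)ncc2C#N)C[C@H]1C`. Its difference from compound 2 is 2-methylcyclopropyl in place of 1-methylcyclopropyl on a carbonyl carbon, with the same atoms joined differently.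

Within the data shown here, one measured step bears on this swap, and it runs the opposite way. Reading a number 0.20 log units lower from compound 1 to compound 2 (within the scatter) backwards, a small upward step is expected in this assay, but none beyond the scatter. Compound 3 differs from compound 2 in more than one place, so it offers no direct comparison. The expected change is a number 0.20 log units higher from compound 2 to compound 4 (within the scatter). For compound 4 the estimated value is 1.9, with an expected range from 1.6 to 2.2.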

Compound 4, distribution coefficient: 2
Estimate against measurement, compound 4: 0.10 log units below, and the stated range covers the measured number.
By their numbers in this assay, from the lowest: compounds 2, 3, 1 and 4 (each within the scatter of the next).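

Compound 4 gives the swap to 2-methylcyclopropyl on a carbonyl carbon a direct reading of its own in this assay as well: a number 0.30 log units higher from compound 2 to compound 4 (within the scatter) and so no separation from the 1-methylcyclopropyl compound. That makes two compounds drawn with 2-methylcyclopropyl that sit level with compound 2, where before there was only one. The two also sit level with each other, at a number 0.10 log units higher from compound 1 to compound 4 (within the scatter) and this step cannot be read as one spatial arrangement of the ring against another, because of one thing: the fact that one of compounds 1 and 4 is drawn with a defined configuration and the other without, at the place where they differ.

On these data alone, whether each separately drawn configuration of 2-methylcyclopropyl would give the same number stays open. So does whether a group of another kind on the carbonyl carbon, such as a longer chain or an amine, would move the number beyond the scatter.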